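Branching the Benzyl Arm and Dropping the Hydroxyethoxy Chain

The source may report more compounds than this note shows. Statements on the series, on what has been measured and on what is new or still open speak of the compounds shown alone.

Compound 3 `Cc1ccc2[nH]c(=O)c(CN(Cc3ccc(OCCO)cc3)Cc3ccc(C(C)(C)C)cc3)cc2c1` belongs to a small set sharing one core and two substituted benzyl groups on an amine nitrogen. In a toxicity assay on MDCK cells (Canis lupus familiaris) for cytotoxicity, read by crystal violet staining, with a stated time of 48 h (on this read-out lower numbers stand for higher toxicity in this test and higher numbers for lower toxicity in this test), compound 3 gives only a limit, > 5000 nM. Its two neighbours are compound 1 `COCOc1ccc(CN(Cc2ccc(C(C)(C)C)cc2)Cc2cc3cc(C)ccc3[nH]c2=O)cc1` and compound 2 `COc1ccc(CN(Cc2ccc(C(C)(C)C)cc2)Cc2cc3cc(C)ccc3[nH]c2=O)cc1`. In this assay compound 1 gives 6400 nM. For compound 2 this assay again reports a limit, > 10000 nM. Compound 3 therefore stands among numbers that all indicate low toxicity: the step that the limit leaves unreadable from compound 1 to compound 3 cannot be sized, the same holds for a step that the two limits leave unreadable from compound 2 to compound 3, and an at least 1.5-fold higher number from compound 1 to compound 2 (0.19 log units; that floor lies within the scatter).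

Compound 4 `COc1ccc(C(C)N(Cc2ccc(C(C)(C)C)cc2)Cc2cc3cc(C)ccc3[nH]c2=O)cc1` differs from compound 3 in one place: 1-(4-methoxyphenyl)ethyl in place of 4-(2-hydroxyethoxy)benzyl on an amine nitrogen. The entering group is, apart from one added methyl, the group that compound 2 carries on the same nitrogen. Going by the values given here, the only sized step that bears on this change is an at least 1.5-fold higher number from compound 1 to compound 2 (0.19 log units; that floor lies within the scatter), and it stays within the scatter; the steps towards compound 3 remain unreadable because of the limit of > 5000 nM in this assay, at which 1 of the 3 values shown sits. No step beyond the scatter is therefore expected in this assay, and compound 4 is expected to behave much like compound 2, which sits at the limit of > 10000 nM in this assay, at which 1 of the 3 values shown sits. Compound 4 is estimated at 12000 nM, between 5000 nM and 30000 nM, so that the expected step that the limit leaves unreadable from compound 3 to compound 4 would itself most likely end at a limit.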

Compound 4, half-maximal cytotoxic concentration: > 5000 nM
Compound 4 was reported as a limit (the forecaster's own chance of this, stated with the estimate: 65%); the middle value is on the limit's open side.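

In this assay compound 4 gives only a limit, > 5000 nM. Going by these compounds alone, no step linking compound 4 with compound 1, compound 2 or compound 3 can be read. The compounds shown leave open whether the added methyl, or the exchange of 4-(2-hydroxyethoxy)benzyl for 1-(4-methoxyphenyl)ethyl, changes the number in this assay at all.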